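The compounds below may be only part of what the source reports. "The series", "measured", "known", "first", "only" and "open" are said of these compounds alone.

Measured so far in a functional assay on A-375 cells (Homo sapiens) for inhibition, read by MTT assay, with a stated time of 4 days; on this read-out higher numbers stand for weaker inhibition and lower numbers for stronger inhibition:
- compound 1 `Cc1cc(N2C[C@@H]3C[C@H]2CN3C)ccc1-c1ccnc2c(-c3cccc4[nH]ncc34)c(-c3ccncc3)nn12` gives 137 nM
- compound 2 `CN1C[C@@H]2CC[C@H]1CN2c1ccc(-c2ccnc3c(-c4cccc5[nH]ncc45)c(-c4ccncc4)nn23)cc1` gives 185 nM
- compound 3 `CN1C[C@@H]2CC[C@H]1CN2c1ccc(-c2ccnc3c(-c4cccc5[nH]ncc45)c(-c4ccncc4)nn23)c(F)c1` gives 118 nM

Compound 3 at 118 nM lies within the scatter of both compound 1 and compound 2, so these pairs cannot be ranked. Compound 4 `Fc1cc(CN2C[C@H]3C[C@@H]2CO3)ccc1-c1ccnc2c(-c3cccc4[nH]ncc34)c(-c3ccncc3)nn12` keeps the fluoro group of compound 3 but exchanges another group (a group of 8 heavy atoms (6 carbon, 1 nitrogen, 1 oxygen; 2 five-membered non-aromatic rings with 1 hetero atom each) in place of a group of 9 heavy atoms (7 carbon, 2 nitrogen; one six-membered non-aromatic ring with 1 hetero atom, one six-membered non-aromatic ring with 2 hetero atoms), on an aromatic carbon). For the measured compounds named here, the only measured single change is a 1.6-fold lower number from compound 2 to compound 3 (0.20 log units; within the scatter) and it concerns the fluoro group, not the exchanged one. Compound 1 at 137 nM carries a different group at that place, yet it stays within the scatter of compound 3, so a large step seems unlikely. From the compounds shown here alone, the new group itself is untested, so the expected change is a 1.5-fold higher number from compound 3 to compound 4 (0.18 log units; within the scatter) and no step beyond the scatter is expected. In this assay compound 4 is estimated at 180 nM (expected range 60 nM to 550 nM).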

Compound 4, half-maximal inhibitory concentration: 78 nM
Estimate against measurement, compound 4: 2.3-fold (0.36 log units) above; the measured number falls inside the stated range.
By their numbers in this assay, from the lowest: compounds 4, 3, 1 and 2 (each within the scatter of the next, the first and the last beyond it).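

In this assay, exchanging the group with two six-membered non-aromatic rings for the one with two five-membered non-aromatic rings, on the aromatic carbon meta to a fluoro group, gives a 1.5-fold lower number from compound 3 to compound 4 (0.18 log units; within the scatter). So this place accepts a different ring set, with an oxygen in place of one nitrogen, without a step beyond the scatter, which the fluoro step alone could not show. No measured evidence on the cause accompanies this result. From the compounds shown here alone, whether a morpholine, a primary amine or a carboxylic acid would also stay within the scatter here remains open. So does how the new group behaves without the fluoro group.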